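From dimethylamino to 2-oxopyrrolidin-1-yl on the shared core

A few compounds are considered here, and "the series" means these few. Any claim that something is new, unique, unknown or untested is made for them only; others in the source may bear on it.

Measured in a physicochemical assay for solubility, measured as kinetic solubility; on this read-out higher numbers stand for higher solubility and lower numbers for lower solubility:
Compound 1 `Cc1n[nH]c(-c2ncc3cccnc3c2O)n1`: > 250000 nM, a limit
Compound 2 `Cc1n[nH]c(-c2ncc3c(N(C)C)ccnc3c2O)n1`: > 250000 nM, a limit

Compound 2 stands only at a limit, > 250000 nM. Compound 1 stands at the same limit, and the limit of > 250000 nM in this assay, at which 2 of the 2 values shown sit, describes both compounds. Compound 3 `Cc1n[nH]c(-c2ncc3c(N4CCCC4=O)ccnc3c2O)n1` carries 2-oxopyrrolidin-1-yl in place of dimethylamino on an aromatic carbon, opposite the ring nitrogen (2-oxopyrrolidin-1-yl in place of dimethylamino on an aromatic carbon). Going by the values given here, the one measured step that bears on this change is a step that the two limits leave unreadable from compound 1 to compound 2, and it gives no size to build on. In this assay, only a modest fall or no readable change is therefore expected, and the expected move is an at least 1.2-fold lower number from compound 2 to compound 3 (0.09 log units; that floor lies within the scatter). For compound 3 the estimate is 200000 nM, with an expected range from 60000 nM to 250000 nM.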

Compound 3, solubility: 109000 nM
Compound 3: middle estimate off by 1.8-fold (0.26 log units), on the high side; the range from low to high includes it.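

Unlike the earlier compounds, compound 3 gives this position, opposite the ring nitrogen, a readable change in this assay: 2-oxopyrrolidin-1-yl in place of dimethylamino gives an at least 2.2-fold lower number from compound 2 to compound 3 (0.36 log units; beyond the scatter), and in place of hydrogen it gives an at least 2.2-fold lower number from compound 1 to compound 3 (0.36 log units; beyond the scatter). The step from compound 1 to compound 2 cannot be read. Both readable steps have only a lower bound on their size because compound 1 and compound 2 stand at a limit: the limit of > 250000 nM in this assay, at which 2 of the 3 values shown sit.

As far as these compounds go, it remains open whether the fall follows the ring or the carbonyl of 2-oxopyrrolidin-1-yl. A plain pyrrolidin-1-yl group, without the carbonyl, would separate the two.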